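Methyl to hydrogen on the aryl ether oxygen: compound 3 to 4

The source may hold more compounds than are shown below. What is called first, only, known or untested is meant among the compounds shown, and "the series" means these compounds.

Compound 1 `CN1CCN(CCCCOc2c(O)cc3oc(-c4ccccc4)cc(=O)c3c2O)CC1`: 82900 nM
Compound 2 `O=c1cc(-c2ccccc2)oc2cc(O)c(OCCCCN3CCCC3)c(O)c12`: 86400 nM
Compound 3 `COc1cc2oc(-c3ccccc3)cc(=O)c2c(O)c1OCCCN1CCCCC1`: 25300 nM

In a functional assay on BCG823 cells (Homo sapiens) for antiproliferative activity, read by MTT assay, with a stated time of 48 h (a lower number here means a stronger inhibitor, a higher number a weaker inhibitor), compound 3 gives the lowest number of the three, and both other compounds lie beyond the scatter from it. Compound 4 `O=c1cc(-c2ccccc2)oc2cc(O)c(OCCCN3CCCCC3)c(O)c12` differs from compound 3 by hydrogen in place of methyl on an oxygen on an aromatic ring. Among the compounds with values here, the only single-place step known, a 1.0-fold higher number from compound 1 to compound 2 (0.02 log units; within the scatter), concerns the amine and says nothing about this change. What the numbers do show is that compound 1 and compound 2, which each carry a hydroxy at this place, give higher numbers than compound 3, though they differ from it elsewhere too. Compound 4 is therefore expected to give a higher number, with the estimated step of a 2.4-fold higher number from compound 3 to compound 4 (0.38 log units; beyond the scatter). Compound 4 is estimated at 60000 nM, in the range 25000 nM to 150000 nM.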

Compound 4, half-maximal inhibitory concentration: 60900 nM
For compound 4 the middle estimate is 1.0-fold (0.01 log units) below the measured one; measured number inside the range.
By their numbers in this assay, from the lowest: compound 3; then compounds 4, 1 and 2 (each within the scatter of the next).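

In this assay, the change from methoxy to hydroxy on the aromatic ring is now seen on its own, as a 2.4-fold higher number from compound 3 to compound 4 (0.38 log units; beyond the scatter). Once the hydroxy is present, the changes in the amine and chain leave the numbers within the scatter, with a 1.4-fold lower number from compound 2 to compound 4 (0.15 log units; within the scatter) and a 1.4-fold lower number from compound 1 to compound 4 (0.13 log units; within the scatter). Nothing measured here accounts for the step from methoxy to hydroxy.

On these data alone, it remains open whether an ethoxy group or a longer alkoxy chain on this oxygen would behave like the methoxy group. As far as these compounds go, it is also open whether the same step would appear with the pyrrolidin-1-yl or 4-methylpiperazin-1-yl amines.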